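Working notes: compound 1 to compound 3

This account rests on a few compounds, and the source may have more. Where it says the series, first, only, none or still open, it means among the compounds named here.

Of the compounds shown here, two have numbers so far. Compound 1 `Cc1cc(Nc2ccn(Cc3nc(C)c4ccccc4n3)n2)n2nc(SCc3ccc(Br)cc3)nc2n1` was run in a functional assay on PC-9 cells (Homo sapiens) for inhibition, read by MTT assay, with a stated time of 72 h (on this read-out lower numbers stand for stronger inhibition and higher numbers for weaker inhibition), and gives 5450 nM. Compound 2 `Cc1cc(Nc2cc(-c3ccccc3)[nH]n2)n2nc(SCc3ccc(C(F)(F)F)cc3)nc2n1` gives 4240 nM in this assay. Compound 1 carries the higher of the two numbers, but its gap to compound 2 lies within the scatter, so no order can be read between them; both sit in the weak range.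

Compound 3 `COc1ccc(Cn2ccc(Nc3cc(C)nc4nc(SCc5ccc(Br)cc5)nn34)n2)cc1` has no number yet. Against compound 1 it differs in one place: 4-methoxyphenyl in place of 4-methylquinazolin-2-yl on a saturated chain carbon bound to an aromatic nitrogen. Cut one bond further out, the same change reads (4-methylquinazolin-2-yl)methyl to 4-methoxybenzyl. The shared core and the rest of the molecule are untouched.

Among the measured compounds shown here, no measured pair shows this change, so its size is unknown here. The step of a 1.4-fold higher number from compound 1 to compound 3 (0.14 log units; within the scatter) is expected to be small, toward a somewhat higher number, and not far beyond the scatter. Since compound 1 gives 5450 nM, compound 3 is estimated at 7500 nM, with a range from 2500 nM to 22000 nM.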

Compound 3, half-maximal inhibitory concentration: > 50000 nM
Compound 3: a limit, no number; the forecaster's own chance of this, stated with the estimate: 10%; middle value at least 6.6-fold (0.82 log units) away from the limit.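

In this assay compound 3 gives > 50000 nM, which is a limit of the assay and not a number. The series now has its first readable step, an at least 9.1-fold higher number from compound 1 to compound 3 (0.96 log units; beyond the scatter), and it shows that the group on the saturated chain carbon bound to an aromatic nitrogen matters to this read-out: 4-methoxyphenyl in place of 4-methylquinazolin-2-yl goes with weaker inhibition, a change that the two earlier compounds could not show. The full size of the step stays unknown, and the value that bounds it is a limit: the limit of > 50000 nM in this assay, at which 1 of the 3 values shown sits.

This single pair leaves open whether the weaker inhibition follows from losing the 4-methylquinazolin-2-yl group as a whole or only a part of it, and whether the methoxy group of compound 3 plays any part in the result. The compounds shown hold no unsubstituted benzyl, no pyridin-2-ylmethyl and no quinazolin-2-ylmethyl lacking the methyl group at this place, so they cannot separate these possibilities.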